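Turning the cyclopropyl back into a methyl-bearing chain

The source may hold more compounds than are shown below. What is called first, only, known or untested is meant among the compounds shown, and "the series" means these compounds.

Measured compounds:
Compound 1 `C[C@@H](C(=O)O)c1nn(Cc2cn3cc(OCC4CC4)c(Cl)cc3n2)c2ccccc2c1=O`: 182 nM
Compound 2 `O=C(O)Cc1nn(Cc2cn3cc(OCC4CC4)c(Cl)cc3n2)c2ccccc2c1=O`: 4.8 nM
Compound 3 `O=C(O)C1(c2nn(Cc3cn4cc(OCC5CC5)c(Cl)cc4n3)c3ccccc3c2=O)CC1`: 28 nM

In a functional assay on HFL1 cells for antagonist activity at sphingosine 1-phosphate receptor 2 (Homo sapiens), read by ELISA, with a stated time of 24 h (a higher number here means a weaker inhibitor, a lower number a stronger inhibitor), compound 3 gives 28 nM, the second highest of the three numbers, sitting between compound 2 and compound 1. Compound 4 `C[C@H](C(=O)O)c1nn(Cc2cn3cc(OCC4CC4)c(Cl)cc3n2)c2ccccc2c1=O` is not yet measured. The change is 1-carboxyethyl in place of 1-carboxycyclopropyl on an aromatic carbon. It undoes the ring closure seen in a 6.5-fold lower number from compound 1 to compound 3 (0.81 log units; beyond the scatter), but the entering group carries the opposite stereocentre to that of compound 1, so compound 1 is a guide, not a twin. The step of a 5.8-fold higher number from compound 2 to compound 3 (0.77 log units; beyond the scatter) shows that adding carbon to the chain raises the number. For compound 4 a higher number than compound 3 is expected, a 2.9-fold higher number from compound 3 to compound 4 (0.46 log units; beyond the scatter), with wide uncertainty because of a 6.5-fold lower number from compound 1 to compound 3 (0.81 log units; beyond the scatter). The estimate for compound 4 is 80 nM, between 10 nM and 500 nM.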

Compound 4, half-maximal inhibitory concentration: 2.1 nM
Compound 4: middle estimate off by 38-fold (1.58 log units), on the high side; measured number below the stated range.
By their numbers in this assay, from the lowest: compound 4; then compound 2; then compound 3; then compound 1.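

In this assay, the drawn configuration of the 1-carboxyethyl group matters greatly, with an 87-fold lower number from compound 1 to compound 4 (1.94 log units; beyond the scatter), and this gap traces to the stereocentre alone: the fact that compounds 1 and 4 differ only in the configuration as drawn. A methyl on this carbon therefore does not raise the number in every case, since the form drawn S gives a 2.3-fold lower number from compound 2 to compound 4 (0.36 log units; beyond the scatter). Replacing 1-carboxycyclopropyl with this same form gives a 13-fold lower number from compound 3 to compound 4 (1.12 log units; beyond the scatter).

The compounds shown leave open how an ethyl in place of that methyl, drawn S, would read. They also leave open how an amide in place of the carboxylic acid would read.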